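Replacing the aryl group on the amide nitrogen: compound 3

The source may report more compounds than this note shows. Statements on the series, on what has been measured and on what is new or still open speak of the compounds shown alone.

Measured compounds:
Compound 1, `O=C(NO)c1ccc(N(Cc2ccc(C3CCCCC3)cn2)C(=O)[C@H]2CCN2S(=O)(=O)c2c(F)c(F)c(F)c(F)c2F)c(F)c1`, 5800 nM
Compound 2, `CNC(=O)c1ccc(N(Cc2ccc(C3CCCCC3)cn2)C(=O)[C@H]2CCN2S(=O)(=O)c2c(F)c(F)c(F)c(F)c2F)cc1O`, 1800 nM

Both compounds were tested in a functional assay on MDA-MB-231 cells (Homo sapiens) for antiproliferative activity, with a stated time of 72 h; a lower number here means that less compound is needed, a higher number that more compound is needed for the effect. Among the two numbers known, compound 2 stands lowest; its nearest neighbour is compound 1, whose step to it, a 3.2-fold lower number from compound 1 to compound 2 (0.51 log units; beyond the scatter), exchanged one aryl group on the amide-type nitrogen for another. Compound 3, `O=C([C@H]1CCN1S(=O)(=O)c1c(F)c(F)c(F)c(F)c1F)N(Cc1ccc(C2CCCCC2)cn1)c1ccc2c(=O)[nH]cnc2c1`, is not yet measured. It differs from compound 2 at that same nitrogen: a group of 11 heavy atoms (8 carbon, 2 nitrogen, 1 oxygen; one six-membered aromatic ring of carbon only, one six-membered aromatic ring with 2 hetero atoms) in place of a group of 11 heavy atoms (8 carbon, 1 nitrogen, 2 oxygen; one six-membered aromatic ring of carbon only), on an amide-type nitrogen. The step from compound 1 to compound 2 is the only one that bears on this position, and it shows that swapping the aryl group there moves the number modestly. The entering group has no common name and is not represented among the measured compounds, so the direction is uncertain. The estimate for compound 3 is 3000 nM, with a range from 700 nM to 13000 nM, which means an expected step of a 1.7-fold higher number from compound 2 to compound 3 (0.22 log units; within the scatter).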

Compound 3, half-maximal effective concentration: 3300 nM
Beside the measured number, compound 3's estimate is 1.1-fold (0.04 log units) below it, and the stated range covers the measured number.
By their numbers in this assay, from the lowest: compounds 2, 3 and 1 (each within the scatter of the next, the first and the last beyond it).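

In this assay, the new group on the amide-type nitrogen gives a number within the scatter of both earlier compounds (a 1.8-fold higher number from compound 2 to compound 3 (0.26 log units; within the scatter); a 1.8-fold lower number from compound 1 to compound 3 (0.24 log units; within the scatter)). Unlike compound 1 and compound 2, compound 3 has neither a hydroxycarbamoyl nor a methylcarbamoyl group on its aryl group, so among these three compounds, neither group is needed for a number in this range. No measurement is available to explain why these different groups give such similar numbers.

A plain phenyl group or a 4-carboxyphenyl group at this nitrogen could show whether the number depends on the substituents on the aryl group or mainly on the presence of an aryl group. As far as these compounds go, whether any group here can give a much lower number also remains open.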